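A few compounds are considered here, and "the series" means these few. Any claim that something is new, unique, unknown or untested is made for them only; others in the source may bear on it.

Compounds 1, 2 and 3 share one core bearing an amide. For the measured compounds named here, compound 2 `Cn1cc([N+](=O)[O-])c(C(=O)Nc2ccc3[nH]c(-c4ccccc4)nc3c2)n1` gives 17300 nM in an ADME assay on Huh-7 cells (Homo sapiens) for cytotoxicity (a higher number here means that more compound is tolerated, a lower number that less compound is tolerated), the lowest of the two numbers measured so far; its nearest neighbour, compound 1 `Cn1ncc([N+](=O)[O-])c1C(=O)Nc1ccc2[nH]c(-c3ccccc3)nc2c1`, gives 34500 nM, and the step of a 2.0-fold lower number from compound 1 to compound 2 (0.30 log units; within the scatter) lies within the scatter. Compound 3 `Nc1ccc(C(=O)Nc2ccc3[nH]c(-c4ccccc4)nc3c2)cc1` is not yet measured. It differs from compound 2 in one place: 4-aminophenyl in place of 1-methyl-4-nitro-1H-pyrazol-3-yl on a carbonyl carbon. Going by the values given here, the only measured step, a 2.0-fold lower number from compound 1 to compound 2 (0.30 log units; within the scatter), concerns the exchange of 1-methyl-4-nitro-1H-pyrazol-5-yl for 1-methyl-4-nitro-1H-pyrazol-3-yl and does not bear on the replacement by 4-aminophenyl; no measured pair shows that change. With nothing pointing either way, no step beyond the scatter is expected in this assay, so the estimated step of a 1.2-fold higher number from compound 2 to compound 3 (0.06 log units; within the scatter) is set near no change. Compound 3 is accordingly expected to give about 20000 nM, with a range from 7000 nM to 60000 nM.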

Compound 3, half-maximal cytotoxic concentration: < 5000 nM
Compound 3 ended at the assay's limit; the forecaster's own chance of this, stated with the estimate: 20%; middle value at least 4.0-fold (0.60 log units) from the limit.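

In this assay compound 3 gives < 5000 nM, which is a limit of the assay and not a number. The group on the carbonyl carbon does matter for this read-out: 4-aminophenyl in place of 1-methyl-4-nitro-1H-pyrazol-3-yl gives an at least 3.4-fold lower number from compound 2 to compound 3 (0.53 log units; beyond the scatter), and 4-aminophenyl in place of 1-methyl-4-nitro-1H-pyrazol-5-yl gives an at least 6.9-fold lower number from compound 1 to compound 3 (0.83 log units; beyond the scatter). The exchange between the two pyrazolyl groups stayed within the scatter, whereas replacing either of them with 4-aminophenyl goes beyond it, with less compound tolerated.

The change swaps the ring and its substituent at once, so the compounds shown do not separate the effect of the amine from that of the carbon-only ring; a 4-nitrophenyl or an unsubstituted phenyl group would do so. The full size of both steps also stays open: the limit of < 5000 nM in this assay, at which 1 of the 3 values shown sits.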